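Swapping a Benzoxazole Thioether for a Methylpiperazine

A few compounds are considered here, and "the series" means these few. Any claim that something is new, unique, unknown or untested is made for them only; others in the source may bear on it.

Of the compounds shown here, three built on a shared core have been measured in a functional assay on HT-29 cells (Homo sapiens) for cytotoxicity, read by MTT assay, with a stated time of 24 h, tested at 1.6 ug/mL; a higher number here means a stronger effect of the compound at the concentration tested, a lower number a weaker effect. Compound 1 `Cn1c(-c2ccc(NC(=O)CSc3nc4ccccc4o3)cc2)nc(-c2ccccc2)c1-c1ccccc1` gives 41% there, the second highest of the three numbers. Compound 3 `Cn1nnnc1SCC(=O)Nc1ccc(-c2nc(-c3ccccc3)c(-c3ccccc3)n2C)cc1` gives 49.8%, and compound 2 `Cn1c(-c2ccc(NC(=O)CSc3nc4cc(Cl)ccc4o3)cc2)nc(-c2ccccc2)c1-c1ccccc1` gives 17.4%. The step of a number 8.8 percentage points higher from compound 1 to compound 3 (within the scatter) lies within the scatter, so compounds 1 and 3 cannot be told apart on these numbers. The step of a number 23.6 percentage points lower from compound 1 to compound 2 (beyond the scatter) is beyond the scatter, and so is a number 32.4 percentage points higher from compound 2 to compound 3 (beyond the scatter).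

Compound 4 `CN1CCN(CC(=O)Nc2ccc(-c3nc(-c4ccccc4)c(-c4ccccc4)n3C)cc2)CC1` has not yet been measured. It differs from compound 1 by 4-methylpiperazin-1-yl in place of (1,3-benzoxazol-2-yl)sulfanyl on a saturated chain carbon bound to a carbonyl carbon. Going by the values given here, the only measured step that touches the same part of the molecule is the one from compound 1 to compound 3, where one ring on the sulfur was exchanged for another and the number moved only within the scatter. Among the compounds with values here, compound 4, however, gives up the sulfur together with its aromatic ring and takes on a non-aromatic ring with two nitrogens; no measured pair shows a change of that kind, so the guidance is weak. The expectation is that compound 4 lands near compound 1, and the step of a number 3 percentage points lower from compound 1 to compound 4 (within the scatter) is the estimate. Compound 4 is therefore expected to give about 38% in this assay, between 12% and 62%.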

Compound 4, a percentage reported as activity, at one concentration (the size of the read-out at that concentration, not a potency): 27.4%
For compound 4 the middle estimate is 10.6 percentage points above the measured one, within the range that was stated.
By their numbers in this assay, from the lowest: compounds 2 and 4 (each within the scatter of the next); then compounds 1 and 3 (each within the scatter of the next).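

In this assay, the exchange of one ring on the sulfur gave only a number 8.8 percentage points higher from compound 1 to compound 3 (within the scatter), but replacing the whole sulfur-linked group on this saturated chain carbon does more: 4-methylpiperazin-1-yl brings a number 13.6 percentage points lower from compound 1 to compound 4 (beyond the scatter) and also a number 22.4 percentage points lower from compound 3 to compound 4 (beyond the scatter). Set against the chlorinated thioether, the same change gives a number 10 percentage points higher from compound 2 to compound 4 (within the scatter), so compounds 2 and 4 cannot be told apart, and the group at this place can match the effect of the chloro substituent on the benzoxazole ring in compound 2 on this read-out. Nothing measured here explains why the number falls when the sulfur-linked ring gives way to the methylpiperazine.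

The sulfur and the aromatic ring leave together in compound 4, so the compounds shown do not tell which part of the change accounts for the lower number. A morpholine ring, a piperazine without the methyl group, or an open-chain dimethylamino group at the same place would show whether the methylpiperazine ring itself matters or any amine on this carbon gives a similar number.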